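Phenyl in place of pyridin-3-yl on the core of compound 3

This account rests on a few compounds, and the source may have more. Where it says the series, first, only, none or still open, it means among the compounds named here.

Compound 3 `CN(C)CCCCOC(=O)Nc1ccc(Cn2nc(-c3cccnc3)c3ccccc3c2=O)cc1` gives 68000 nM in an ADME assay on Huh-7 cells (Homo sapiens) for cytotoxicity, read by MTT assay, with a stated time of 48 h; a higher number here means that more compound is tolerated, a lower number that less compound is tolerated. Among the three measured compounds this is the highest number, yet compound 2 `CN(C)CCCCOC(=O)Nc1ccc(Cn2nc(-c3ccncc3)c3ccccc3c2=O)cc1` at 62700 nM lies within the scatter of it; compound 1 `CC(c1ccc(N(CCCCN(C)C)C(=O)O)cc1)n1nc(-c2ccc(F)cc2)c2ccccc2c1=O`, which differs in several places, gives 15200 nM. Compound 4 `CN(C)CCCCOC(=O)Nc1ccc(Cn2nc(-c3ccccc3)c3ccccc3c2=O)cc1` carries phenyl in place of pyridin-3-yl on an aromatic carbon. For the measured compounds named here, the only measured step at this position is a 1.1-fold higher number from compound 2 to compound 3 (0.04 log units; within the scatter), which stayed within the scatter; no measured step swaps a pyridinyl ring for phenyl, so the change is not directly covered. On that basis the step of a 1.1-fold lower number from compound 3 to compound 4 (0.05 log units; within the scatter) is expected to remain within the scatter. Compound 4 is estimated at 60000 nM, with a range from 28000 nM to 130000 nM.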

Compound 4, half-maximal cytotoxic concentration: 16000 nM
For compound 4 the middle estimate is 3.8-fold (0.57 log units) above the measured one, and the stated range ends above it.
By their numbers in this assay, from the lowest: compounds 1 and 4 (each within the scatter of the next); then compounds 2 and 3 (each within the scatter of the next).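

In this assay, replacing either pyridinyl ring with phenyl gives a 4.3-fold lower number from compound 3 to compound 4 (0.63 log units; beyond the scatter) and a 3.9-fold lower number from compound 2 to compound 4 (0.59 log units; beyond the scatter), both beyond the scatter. The place of the ring nitrogen made no difference beyond the scatter, a 1.1-fold higher number from compound 2 to compound 3 (0.04 log units; within the scatter), whereas its absence from this ring does, so compound 2 and compound 3 stand apart from compound 4. No measurement available here accounts for the difference.

Still open, from the compounds shown here alone, is whether a pyrimidinyl ring or an aminophenyl ring on this aromatic carbon would fall with compound 2 and compound 3 or with compound 4 in this assay.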